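The source may hold more compounds than are shown below. What is called first, only, known or untested is meant among the compounds shown, and "the series" means these compounds.

Of the compounds shown here, three of a shared core have been measured in an assay on cell membranes for displacement of a labelled ligand from Neuronal acetylcholine receptor; alpha4/beta2 (Rattus norvegicus); on this read-out lower numbers stand for stronger inhibition and higher numbers for weaker inhibition. Compound 1 `CN(c1ccccc1)c1ccc(N2CC3CC(C2)N3)nn1` gives 1430 nM. Compound 2 `Fc1ccc(Nc2ccc(N3CC4CC(C3)N4)nn2)cc1` gives 868 nM, and compound 3 `Fc1ccc(Nc2cncc(N3CC4CC(C3)N4)c2)cc1` gives 0.091 nM. Compound 2 therefore stands at the higher end of the three numbers: its nearest neighbour is compound 1, whose value lies within the usual scatter of its own, so the two cannot be told apart, while compound 3 lies far below both, well beyond the scatter.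

Compound 4 `Cc1ccc(Nc2ccc(N3CC4CC(C3)N4)nn2)cc1` differs from compound 2 in one place: methyl in place of fluoro on an aromatic carbon. Within the data shown here, no measured pair shows this particular exchange on this core, so the data give no direct guide to its size. A swap of two small neutral groups of one heavy atom each, with no change in ring count, donors or acceptors, is expected to move this assay little, in no particular direction beyond the scatter. The step of a 1.2-fold higher number from compound 2 to compound 4 (0.06 log units; within the scatter) is therefore expected to be small. On this basis compound 4 is estimated at 1000 nM, with a range from 300 nM to 3500 nM.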

Compound 4, inhibition constant: 44.3 nM
The estimate for compound 4 lay 23-fold (1.35 log units) above the measured number, and the stated range ends above it.
By their numbers in this assay, from the lowest: compound 3; then compound 4; then compounds 2 and 1 (each within the scatter of the next).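

In this assay the exchange of 4-fluorophenyl for 4-methylphenyl gives a 20-fold lower number from compound 2 to compound 4 (1.29 log units; beyond the scatter) and shows that this position, on an aromatic carbon para to a large group, is sensitive to the identity of its substituent. The exchange replaces one heavy atom with one heavy atom and changes no ring, hydrogen-bond donor, hydrogen-bond acceptor or net charge, yet its step lies beyond the scatter, which no earlier one-place comparison could reveal. Nothing at hand accounts for the size of this step.

The compounds shown leave open whether an ethyl, methoxy or chloro group at this place would follow methyl or fluoro. They also leave open whether the same exchange would produce a step of similar size on the core of compound 3 .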